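The source may report more compounds than this note shows. Statements on the series, on what has been measured and on what is new or still open speak of the compounds shown alone.

The study is an account of a small set of anilides tested in an in vitro functional assay on HEK293-A cells for antagonist activity at metabotropic glutamate receptor 5 (Rattus norvegicus), read by calcium flux; on this read-out higher numbers stand for weaker inhibition and lower numbers for stronger inhibition. Compound 1 `O=C(Nc1ccccc1O)c1cccc(N2C(=O)c3ccccc3C2=O)c1` gives 77 nM in this assay. Going by the values given here, compound 2 `COc1ccccc1C(=O)Nc1cccc(NC(=O)c2ccccc2Cl)c1` is a different case: in this assay compound 2 reaches only the limit of > 30000 nM, so no number is known for it, and it is the one value that sits at the limit of > 30000 nM in this assay, at which 1 of the 2 values shown sits. Among the compounds with values here, no step between the two measured compounds is given, so their two values stand side by side without a comparison of size.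

From compound 2 the path leads to compound 3 `COc1ccccc1C(=O)Nc1cccc(NC(=O)c2ccc(Cl)cc2)c1`, which has not yet been measured in this assay. The change is 4-chlorophenyl in place of 2-chlorophenyl on a carbonyl carbon; the two compounds hold the same atoms joined differently, and nothing else on the shared core moves. Because compound 2 sits at the limit of > 30000 nM in this assay, at which 1 of the 2 values shown sits, only a move in the direction of stronger inhibition could bring a measurable number. Compound 3 is expected to stay weak, with a step of an at least 1.5-fold lower number from compound 2 to compound 3 (0.17 log units; that floor lies within the scatter) at most beyond the scatter. The estimate for compound 3 in this assay is 20000 nM, within a range of 5000 nM to 60000 nM.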

Compound 3, half-maximal inhibitory concentration: > 30000 nM
Compound 3: a limit, no number; the forecaster's own chance of this, stated with the estimate: 60%; middle value at least 1.5-fold (0.17 log units) from the limit.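

No step from compound 2 to compound 3 can be read in this assay, because both results are limits and not numbers: the limit of > 30000 nM in this assay, at which 2 of the 3 values shown sit.

The compounds shown leave open whether 4-chlorophenyl in place of 2-chlorophenyl on a carbonyl carbon changes inhibition at all, since neither compound gives a number that could show it.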